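The source may hold more compounds than are shown below. What is called first, only, known or untested is meant among the compounds shown, and "the series" means these compounds.

Among the compounds with values here, in a functional assay on A-431 cells (Homo sapiens) for inhibition, read by MTT assay, with a stated time of 72 h (on this read-out higher numbers stand for weaker inhibition and lower numbers for stronger inhibition), two compounds have numbers so far. Compound 1 (`O=C(NCc1nnc(SCCCN2CCN(c3nc4ccccc4o3)CC2)o1)c1ccccc1`) gives 36900 nM, and compound 2 (`Oc1ccc(-c2nnc(SCCCN3CCN(c4nc5ccccc5s4)CC3)o2)cc1`) gives 54700 nM. These two values lie within the usual scatter of repeated measurements, so compound 2 stands level with compound 1 on the evidence available.

The unmeasured compound 3 (`O=C(NCc1nnc(SCCCN2CCN(c3nc4ccccc4s3)CC2)o1)c1ccccc1`) keeps the rest of compound 2 and changes one group. It has benzamidomethyl in place of 4-hydroxyphenyl on an aromatic carbon of a five-membered aromatic ring with 2 nitrogen and 1 oxygen: benzamidomethyl in place of 4-hydroxyphenyl on an aromatic carbon.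

Within the data shown here, no two measured compounds differ in just one place, so no direct step is available as a guide, and any expectation stays rough. A step no larger than the scatter is expected in this assay, because compound 1 with the same benzamidomethyl group gives 36900 nM. The expected change is a 1.4-fold lower number from compound 2 to compound 3 (0.14 log units; within the scatter), which is too small to count as a real shift in either direction. For compound 3 the estimated value is 40000 nM, with an expected range of 18000 nM to 90000 nM.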

Compound 3, half-maximal inhibitory concentration: 55900 nM
The estimate for compound 3 lay 1.4-fold (0.15 log units) below the measured number; the measured number falls inside the stated range.
By their numbers in this assay, from the lowest: compounds 1, 2 and 3 (each within the scatter of the next).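

In this assay, placing benzamidomethyl in place of 4-hydroxyphenyl on the aromatic carbon of the five-membered ring gives a 1.0-fold higher number from compound 2 to compound 3 (0.01 log units; within the scatter), so this position now has its first direct comparison, and these two groups cannot be told apart there, even though they differ in size and benzamidomethyl brings an added double bond outside the aromatic rings. The second direct comparison concerns the other end of the molecule, where 1,3-benzothiazol-2-yl in place of 1,3-benzoxazol-2-yl on the ring amine nitrogen gives a 1.5-fold higher number from compound 1 to compound 3 (0.18 log units; within the scatter), so that change also produces no real shift in this assay. No measurement of any other kind is available to help interpret these two results.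

The compounds shown leave open whether anything at the aromatic carbon can move the number beyond the scatter, for example a carboxylic acid or a simple amine in place of benzamidomethyl. They also leave open whether a longer chain between the sulfur and the ring amine nitrogen, or a plain phenyl in place of 1,3-benzothiazol-2-yl, would change the result.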